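Compound 4: a methoxyphenyl analogue of the sulfonamide series

The source may report more compounds than this note shows. Statements on the series, on what has been measured and on what is new or still open speak of the compounds shown alone.

Of the compounds shown here, three of one core have been measured in a functional assay on Ehrlich cells (Mus musculus) for antiproliferative activity, read by trypan blue exclusion, with a stated time of 2 h, tested at 100 ug/mL; a lower number here means a weaker effect, a higher number a stronger effect of the compound at the concentration tested. Compound 1 `N#CC1=C(N)N(c2ccc(S(N)(=O)=O)cc2)C2=C(C(=O)CCC2)C1c1ccccc1` gives 40%, compound 2 `N#CC1=C(N)N(c2ccc(S(N)(=O)=O)cc2)C2=C(C(=O)CCC2)C1c1ccc(O)cc1` gives 100%, and compound 3 `N#CC1=C(N)N(c2ccc(S(N)(=O)=O)cc2)C2=C(C(=O)CCC2)C1/C=C/c1ccccc1` gives 45%. Compound 3 therefore stands second highest of the three: its nearest neighbour is compound 1, within the scatter, while compound 2 lies far above it, a number 55 percentage points lower from compound 2 to compound 3 (beyond the scatter).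

Compound 4 `COc1ccccc1C1C(C#N)=C(N)N(c2ccc(S(N)(=O)=O)cc2)C2=C1C(=O)CCC2` differs from compound 3 in one place: 2-methoxyphenyl in place of 2-phenylethenyl on a saturated ring carbon. Within the data shown here, two measured steps bear on this. The step of a number 5 percentage points higher from compound 1 to compound 3 (within the scatter) shows that 2-phenylethenyl and phenyl on this saturated ring carbon give numbers within the scatter of each other. The step of a number 60 percentage points higher from compound 1 to compound 2 (beyond the scatter) shows that a hydroxy on the aromatic ring raised the read-out strongly. Among the measured compounds shown here, compound 4 carries a methoxy, not a hydroxy, and no measured compound tells what a 2-methoxyphenyl does here. The expectation for compound 4 is therefore a number close to that of compound 3, a number 5 percentage points higher from compound 3 to compound 4 (within the scatter), within the scatter. Compound 4 is estimated at 50% in this assay, with a range from 30% to 80%.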

Compound 4, a percentage reported as activity, at one concentration (the size of the read-out at that concentration, not a potency): 0%
For compound 4 the middle estimate is 50 percentage points above the measured one, outside the stated range (below it).
By their numbers in this assay, from the lowest: compound 4; then compounds 1 and 3 (each within the scatter of the next); then compound 2.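

In this assay, a substituent on the aromatic ring at this saturated ring carbon can lower the read-out as well as raise it: a methoxy group added to that ring gives a clear loss (a number 40 percentage points lower from compound 1 to compound 4 (beyond the scatter)), where the hydroxy of compound 2 had given a gain. The 2-methoxyphenyl group also does not stand in for either of the other groups at this position (a number 45 percentage points lower from compound 3 to compound 4 (beyond the scatter); a number 100 percentage points lower from compound 2 to compound 4 (beyond the scatter)). Nothing available accounts for this loss.

The compounds shown leave open whether the loss follows the methoxy group itself or its place on the aromatic ring, a question that a 4-methoxyphenyl or a 2-hydroxyphenyl group would settle. From the compounds shown here alone, how a 2-chlorophenyl or a 2-aminophenyl group would read here also remains open.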